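Swapping a Pyrrole for a Furan on a Cyanoacrylamide

A few compounds are considered here, and "the series" means these few. Any claim that something is new, unique, unknown or untested is made for them only; others in the source may bear on it.

Of the compounds shown here, three have been measured in a functional assay on NCI-H460 cells (Homo sapiens) for inhibition, read by MTT assay, with a stated time of 72 h; on this read-out higher numbers stand for weaker inhibition of growth and lower numbers for stronger inhibition of growth. Compound 1 `N#C/C(=C\c1c(F)c(F)c(F)c(F)c1F)C(=O)c1c[nH]c2ccccc12` gives 35000 nM in this assay. Compound 2 `N#C/C(=C\c1c[nH]c2ccccc12)C(=O)c1c[nH]c2ccccc12` gives 7600 nM in this assay. Compound 3 `COc1ccc(CNC(=O)/C(C#N)=C/c2ccc[nH]2)cc1` gives only a limit in this assay, > 50000 nM, and not a number; this is the limit of > 50000 nM in this assay, at which 1 of the 3 values shown sits. The values of compound 1 and compound 2 show compound 2 with the lower number, but no single-change step connects any pair of these three compounds, so nothing can be said about which part of the structures accounts for that difference.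

Compound 4 `COc1ccc(CNC(=O)/C(C#N)=C/c2ccoc2)cc1` has not yet been measured. It differs from compound 3 in one place: furan-3-yl in place of 1H-pyrrol-2-yl on a double-bonded chain carbon bound to a double-bonded chain carbon. Because compound 3 stands at a limit in this assay, > 50000 nM, no direction can be read from the measured compounds, and the change is one five-membered ring with one hetero atom replaced by another on a double-bonded chain carbon. Compound 4 is therefore expected to sit at or near the same limit, and the expected step is a step that the limit leaves unreadable from compound 3 to compound 4, not beyond the usual scatter. The value of compound 4 in this assay is estimated at 60000 nM, with a range from 20000 nM to 200000 nM.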

Compound 4, concentration for 50% growth inhibition: 8000 nM
Compound 4: middle estimate off by 7.5-fold (0.88 log units), on the high side; measured number outside the range, below it.
By their numbers in this assay, from the lowest: compounds 2 and 4 (each within the scatter of the next); then compound 1. At a limit, above all of these: compound 3.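

In this assay, the ring on this double-bonded chain carbon matters: replacing 1H-pyrrol-2-yl with furan-3-yl gives an at least 6.2-fold lower number from compound 3 to compound 4 (0.79 log units; beyond the scatter). For the compounds shown here, this is the first difference in the set that can be tied to one place in the structure, since the earlier compounds offered no single-change pair. The true size of the step remains unknown because compound 3 stands at a limit rather than at a number: the limit of > 50000 nM in this assay, at which 1 of the 4 values shown sits.

The swap changes several things at once: the hetero atom goes from nitrogen to oxygen, the ring is joined through a different ring position, and the hydrogen-bond donor of the pyrrole gives way to the hydrogen-bond acceptor of the furan, so the compounds shown cannot say which of these matters. Furan-2-yl and 1H-pyrrol-3-yl at this place would help pull these apart, and thiophen-3-yl, with sulfur as the hetero atom, or a plain phenyl ring would show whether the gain in growth inhibition depends on the oxygen at all.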